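Furan-2-yl for Vinyl: Cytotoxicity Expected to Stay Flat

This account rests on a few compounds, and the source may have more. Where it says the series, first, only, none or still open, it means among the compounds named here.

Three compounds sharing a common core have so far been run in an ADME assay on PC-3 cells (Homo sapiens) for cytotoxicity, read by WST assay, tested at 100 uM; on this read-out lower numbers stand for less inhibition and higher numbers for more inhibition at the one concentration tested (going by the name of the read-out). Compound 1 `O=C(Nc1cccc(Oc2nccc(C(F)(F)F)c2Cl)c1)C1CCCN(C(=O)c2cc(C(F)(F)F)cc(C(F)(F)F)c2)C1` gives 0% in this assay. Compound 2 `O=C(Nc1cccc(Oc2ccccn2)c1)C1CCCN(C(=O)c2cc(C(F)(F)F)cc(C(F)(F)F)c2)C1` gives 0%, and the step of no change at the digits printed from compound 1 to compound 2 (within the scatter) shows that swapping pyridin-2-yl for 3-chloro-4-(trifluoromethyl)pyridin-2-yl on the aryl ether oxygen left the read-out where it was. Compound 3 `C=Cc1cccc(C(=O)N2CCCC(C(=O)Nc3ccc(Cl)cc3)C2)c1` gives 0%, level with compounds 1 and 2 at the digits recorded; the pair with compound 1 and the pair with compound 2 both lie within the scatter.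

Compound 4 `O=C(Nc1ccc(Cl)cc1)C1CCCN(C(=O)c2cccc(-c3ccco3)c2)C1` differs from compound 3 by furan-2-yl in place of vinyl on an aromatic carbon. Going by the values given here, no measured step touches this position, so the only guidance is indirect: every change tried so far, including the step of no change at the digits printed from compound 1 to compound 2 (within the scatter), has left the read-out flat, and all three measured compounds sit at the floor of the scale. On that basis the step of no change at the digits printed from compound 3 to compound 4 (within the scatter) is expected to stay within the scatter, with no movement in either direction that could be told from noise.

Compound 4 is therefore estimated to give 0% in this assay, with a range from -8% to 10%.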

Compound 4, a percentage reported as inhibition, at one concentration (the size of the read-out at that concentration, not a potency): 0%
The estimate for compound 4 equals the measured number at the digits printed; the measured number falls inside the stated range.
By their numbers in this assay, from the lowest: compounds 1, 2, 3 and 4 (each within the scatter of the next).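

In this assay, going by these compounds alone, the step of no change at the digits printed from compound 3 to compound 4 (within the scatter) gives the first reading at this position, an aromatic carbon of a six-membered aromatic ring of carbon only, meta to a large group. It shows that the number stays level with a much larger replacement at this position, without a change that can be told from the scatter: furan-2-yl, with 5 heavy atoms, a five-membered aromatic ring and a hydrogen-bond acceptor, reads the same as vinyl, with 2 heavy atoms, no ring and no hydrogen-bond acceptor. No measurement is available that would account for this outcome.

The compounds shown leave open whether an amine, a carboxylic acid or a longer chain on this aromatic carbon would move the reading in this assay at all. They also leave open whether furan-2-yl would read the same on the core of compound 1, where the groups around the shared core are different.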